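The compounds below may be only part of what the source reports. "The series", "measured", "known", "first", "only" and "open" are said of these compounds alone.

Measured so far:
Compound 1 `CCCCCCCCCCn1cc(-c2nc3ccccc3cc2C)nn1` gives a limit, > 100 ug/mL.
Compound 2 `CCCCCCCCCCn1cc(-c2nc3ccccc3cc2CCCC)nn1`: 25.2 ug/mL.
Compound 3 `CCCCCc1cc2ccccc2nc1-c1cn(-c2ccc(F)cc2)nn1`: 67.5 ug/mL.

In a functional assay on U-937 cells (Homo sapiens) for cytotoxicity, read by MTT assay, with a stated time of 24 h (a higher number here means a weaker inhibitor, a lower number a stronger inhibitor), compound 2 gives 25.2 ug/mL. Compound 1 gives only a limit, > 100 ug/mL. The step of an at least 3.9-fold higher number from compound 2 to compound 1 (0.59 log units; beyond the scatter) comes with the change (hydrogen in place of propyl on a saturated chain carbon bound to an aromatic carbon). In this assay compound 3 gives 67.5 ug/mL; compound 3 and compound 2 differ in more than one place, and the difference between the two cores is not broken down here. Compound 4 `CCc1cc2ccccc2nc1-c1cn(-c2ccc(F)cc2)nn1` is not yet measured; it differs from compound 3 by hydrogen in place of propyl on a saturated chain carbon, two bonds along the chain from an aromatic carbon, the same kind of change as from compound 2 to compound 1, but at a different place, two bonds along the chain from an aromatic carbon rather than bound to an aromatic carbon. Judged by the earlier step of an at least 3.9-fold higher number from compound 2 to compound 1 (0.59 log units; beyond the scatter), a step of similar size is expected, a 2.4-fold higher number from compound 3 to compound 4 (0.37 log units; beyond the scatter), which would carry compound 4 to the limit (the limit of > 100 ug/mL in this assay, at which 1 of the 3 values shown sits). Compound 4 is therefore estimated at 160 ug/mL, between 70 ug/mL and 400 ug/mL.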

Compound 4, half-maximal inhibitory concentration: > 100 ug/mL
Compound 4 gave a limit, no number; the forecaster's own chance of this, stated with the estimate: 65%; the middle value lies beyond the limit too.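

In this assay compound 4 gives only a limit, > 100 ug/mL. With hydrogen in place of propyl, the step reads an at least 1.4-fold higher number from compound 3 to compound 4 (0.17 log units; that floor lies within the scatter), so its floor alone does not secure a change on this core. The change is compatible with a higher number on both cores, but the size of the step on the core of compound 3 remains unknown, and the comparison does not establish that the change carries over with the same effect: the same change on two cores in this assay, an at least 3.9-fold higher number (0.59 log units; beyond the scatter) from compound 2 to compound 1 and an at least 1.4-fold higher number (0.17 log units; that floor lies within the scatter) from compound 3 to compound 4; the limit leaves it open whether they differ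

The compounds shown leave open how a chain longer than pentyl would read in this assay on the core of compound 3. They also leave open what an amine in that place would give.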